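Aryl variation on the shared core: compound 3 to compound 4

The source may hold more compounds than are shown below. What is called first, only, known or untested is meant among the compounds shown, and "the series" means these compounds.

Compound 3 `CC(C)Cc1ccc(C(C)c2nnc3n2N=C(c2ccc(Cl)cc2Cl)CS3)cc1` gives 7500 nM in a functional assay on Huh-7 cells (Homo sapiens) for inhibition, read by sulforhodamine B assay, with a stated time of 72 h; a lower number here means a stronger inhibitor, a higher number a weaker inhibitor. Of the three measured compounds it holds the second highest number: compound 2 `CC(C)Cc1ccc(C(C)c2nnc3n2N=C(c2ccc(F)cc2)CS3)cc1` gives 7800 nM in this assay, and the step of a 1.0-fold lower number from compound 2 to compound 3 (0.02 log units; within the scatter) lies within the scatter, whereas compound 1 `CC(C)Cc1ccc(C(C)c2nnc3n2N=C(c2ccc(OC(F)(F)F)cc2)CS3)cc1` gives 3600 nM and the step of a 2.2-fold higher number from compound 1 to compound 2 (0.34 log units; beyond the scatter) is a modest move to a weaker inhibitor.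

Compound 4 `COc1ccc(C2=Nn3c(nnc3C(C)c3ccc(CC(C)C)cc3)SC2)cc1` is not yet measured. Its change from compound 3 is 4-methoxyphenyl in place of 2,4-dichlorophenyl on a carbon with a double bond to nitrogen. For the measured compounds named here, both measured steps concern the same aryl group on the same carbon, and the 4-methoxyphenyl itself has no precedent. The exchange of fluoro for trifluoromethoxy gave a 2.2-fold higher number from compound 1 to compound 2 (0.34 log units; beyond the scatter), the exchange of the whole ring gave a 1.0-fold lower number from compound 2 to compound 3 (0.02 log units; within the scatter); neither exceeds a modest size, so for compound 4 a step of about a 1.1-fold lower number from compound 3 to compound 4 (0.03 log units; within the scatter) is expected, with no clear direction beyond the scatter. Compound 4 is therefore estimated at 7000 nM in this assay, with a range from 3000 nM to 16000 nM.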

Compound 4, half-maximal inhibitory concentration: 3700 nM
For compound 4 the middle estimate is 1.9-fold (0.28 log units) above the measured one; the range from low to high includes it.
By their numbers in this assay, from the lowest: compounds 1 and 4 (each within the scatter of the next); then compounds 3 and 2 (each within the scatter of the next).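

In this assay the aryl group on the carbon with a double bond to nitrogen now shows a whole-ring exchange that moves beyond the scatter (a 2.0-fold lower number from compound 3 to compound 4 (0.31 log units; beyond the scatter)), and methoxy in place of fluoro on an aromatic carbon moves the same way and by a similar modest size (a 2.1-fold lower number from compound 2 to compound 4 (0.32 log units; beyond the scatter)). Methyl in place of trifluoromethyl on the oxygen changes nothing beyond the scatter (a 1.0-fold higher number from compound 1 to compound 4 (0.01 log units; within the scatter)), so among these four compounds the two oxygen-linked groups, in compound 1 and compound 4, sit at the low end, with no compound going against this. No data at hand bear on what lies behind these steps.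

From the compounds shown here alone, whether the ring oxygen itself matters stays open, since a plain methyl or ethyl group at the same ring carbon does not appear here. An amine, a hydroxyl or a longer alkoxy chain there is equally untested in the compounds shown.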